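Inserting a Carbonyl Between Piperazine and Aryl Ring

The source may report more compounds than this note shows. Statements on the series, on what has been measured and on what is new or still open speak of the compounds shown alone.

Of the compounds shown here, three sharing one core have been measured in an assay on isolated protein for inhibition of Discoidin domain-containing receptor 2 (Homo sapiens), read by ELISA, with a stated time of 60 min; on this read-out higher numbers stand for weaker inhibition and lower numbers for stronger inhibition. Compound 1 `Cc1ccc(C(=O)Nc2cc(CN3CCN(C)CC3)cc(C(F)(F)F)c2)cc1-c1ccc2cn[nH]c2c1` gives 4.7 nM, compound 2 `Cc1ccc(C(=O)Nc2cc(CN3CCN(C4CCCC4)CC3)cc(C(F)(F)F)c2)cc1-c1ccc2cn[nH]c2c1` gives 7 nM, and compound 3 `Cc1ccc(C(=O)Nc2cccc(C(F)(F)F)c2)cc1-c1ccc2c(-c3ccc(N4CCN(C)CC4)cc3)n[nH]c2c1` gives 8.8 nM. Among the measured compounds shown here, the one single-point step among them, a 1.5-fold higher number from compound 1 to compound 2 (0.17 log units; within the scatter), lies within the scatter. Compound 3 stands as the highest of the three numbers, yet its distance to compound 2 and to compound 1 is within the scatter in each case, so no order among the three can be claimed.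

Compound 4 `Cc1ccc(C(=O)Nc2cccc(C(F)(F)F)c2)cc1-c1ccc2c(-c3ccc(C(=O)N4CCN(C)CC4)cc3)n[nH]c2c1` differs from compound 3 in one place: (4-methylpiperazin-1-yl)carbonyl in place of 4-methylpiperazin-1-yl on an aromatic carbon. For the measured compounds named here, none of the measured steps touches this position. Going by the values given here, the only measured step, from compound 1 to compound 2, exchanges a substituent on the amine nitrogen of a piperazine that sits in a different part of the molecule, and it was within the scatter. No measured change tests whether a carbonyl between the 4-methylpiperazin-1-yl group and the aromatic ring matters in this assay.

With nothing in the data pointing either way, compound 4 is expected to show a step of a 1.1-fold higher number from compound 3 to compound 4 (0.06 log units; within the scatter), that is, no change beyond the scatter. The estimate for compound 4 in this assay is 10 nM, with a range from 4 nM to 28 nM.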

Compound 4, half-maximal inhibitory concentration: 6.5 nM
Estimate against measurement, compound 4: 1.5-fold (0.19 log units) above; the range from low to high includes it.
By their numbers in this assay, from the lowest: compounds 1, 4, 2 and 3 (each within the scatter of the next).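

In this assay the exchange of 4-methylpiperazin-1-yl for (4-methylpiperazin-1-yl)carbonyl, on an aromatic carbon para to a large group, gives a 1.4-fold lower number from compound 3 to compound 4 (0.13 log units; within the scatter) and so no change that can be told from the scatter. Among the compounds shown here, this is the first measured step at this position, and it shows that adding a carbonyl to the group there leaves the read-out indistinguishable from that of the group without it, while the six-membered ring and the terminal methyl stay in place. Nothing available explains why the carbonyl leaves the number within the scatter.

The compounds shown leave open how much more this position can take, since both groups tested carry the same 4-methylpiperazin-1-yl unit, and a morpholine, a carboxylic acid or a longer chain ending in a dimethylamine would test whether that unit matters at all. They also leave open whether the same carbonyl exchange would give so small a step on the core of compound 1, where the piperazine is attached elsewhere.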